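The source may report more compounds than this note shows. Statements on the series, on what has been measured and on what is new or still open speak of the compounds shown alone.

Compound 1 `OC[C@H]1O[C@@H](n2cc(F)c3c(-c4ccc[nH]4)ncnc32)[C@H](O)[C@@H]1O`: 9 nM
Compound 2 `OC[C@H]1O[C@@H](n2cc(F)c3c(-c4ccoc4)ncnc32)[C@H](O)[C@@H]1O`: 5 nM

For the measured compounds named here, in a functional assay on DU-145 cells (Homo sapiens), read by sulforhodamine B assay, with a stated time of 5 days (a higher number here means a weaker inhibitor of growth, a lower number a stronger inhibitor of growth), compound 2 gives 5 nM, which cannot be told apart from compound 1, since the only measured step is a 1.8-fold lower number from compound 1 to compound 2 (0.26 log units; within the scatter). Compound 3 `OC[C@H]1O[C@@H](n2cc(F)c3c(-c4cc[nH]c4)ncnc32)[C@H](O)[C@@H]1O` carries 1H-pyrrol-3-yl in place of furan-3-yl on an aromatic carbon. The measured step bears on this change. It also exchanges a pyrrolyl and a furan-3-yl group, and it stayed small: a 1.8-fold lower number from compound 1 to compound 2 (0.26 log units; within the scatter). No step beyond the scatter is therefore expected in this assay, and no direction can be firmly called. The estimated step is a 1.6-fold higher number from compound 2 to compound 3 (0.20 log units; within the scatter). Compound 3 is expected at 8 nM, within a range of 3 nM to 25 nM.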

Compound 3, concentration for 50% growth inhibition: 10 nM
Compound 3: the middle estimate sits 1.3-fold (0.10 log units) below what was measured, and the stated range covers the measured number.
By their numbers in this assay, from the lowest: compounds 2, 1 and 3 (each within the scatter of the next).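

In this assay, putting 1H-pyrrol-3-yl in place of furan-3-yl on this aromatic carbon gives a 2.0-fold higher number from compound 2 to compound 3 (0.30 log units; within the scatter), so exchanging the ring oxygen for a ring nitrogen with its hydrogen stays within the scatter. Moving from 1H-pyrrol-2-yl to 1H-pyrrol-3-yl gives a 1.1-fold higher number from compound 1 to compound 3 (0.05 log units; within the scatter), so the point of attachment of the pyrrole also stays within the scatter. Nothing available explains these results.

All three groups shown are five-membered aromatic rings with one hetero atom. As far as these compounds go, how an amine or a longer alkyl chain at this position would read remains open.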